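This account rests on a few compounds, and the source may have more. Where it says the series, first, only, none or still open, it means among the compounds named here.

Measured so far:
- Compound 1 `CCCC1=C(OCC(C)C)C(CCC)(CCC)C(=O)/C(=C(O)\C=C\c2ccccc2)C1=O` in a functional assay on PC-3 cells (Homo sapiens) for antiproliferative activity, read by sulforhodamine B assay, with a stated time of 3 days (a higher number here means that more compound is needed for the effect, a lower number that less compound is needed), gives 12.2 uM
- Compound 2 `CCCC1(CC=C(C)C)C(=O)C(C(=O)/C=C/c2ccccc2)=C(O)C(CCC)(CCC)C1=O` in this assay gives 8.4 uM

Compound 1 holds the higher of the two numbers, but the gap to compound 2 sits within the scatter of repeated measurements, so the two cannot be separated on these data. Among the measured compounds shown here, no step between two measured compounds that differ in a single place is available, and compounds 1 and 2 differ at more than one place, so nothing about the effect of a single change can be read from them.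

Compound 3 `CCCOC1=C(CCC)C(=O)/C(=C(O)/C=C/c2ccccc2)C(=O)C1(CCC)CCC` is not yet measured. It differs from compound 1 by hydrogen in place of methyl on a saturated chain carbon bound to two saturated chain carbons; cut one bond further out, the same change reads isobutoxy to propoxy. Nothing in the measured pair speaks to this change. The expectation for the step of a 1.1-fold lower number from compound 1 to compound 3 (0.04 log units; within the scatter) is therefore no movement beyond the scatter, in either direction. Compound 3 is estimated at 11 uM in this assay, with a range from 5 uM to 25 uM that reflects the absence of any measured step of this kind.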

Compound 3, concentration for half-maximal effect: 8.6 uM
The estimate for compound 3 lay 1.3-fold (0.11 log units) above the measured number; the measured number falls inside the stated range.
By their numbers in this assay, from the lowest: compounds 2, 3 and 1 (each within the scatter of the next).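

In this assay, among the compounds shown here, the change from isobutoxy to propoxy provides the first step that differs in one place: a 1.4-fold lower number from compound 1 to compound 3 (0.15 log units; within the scatter). Hydrogen in place of methyl on this saturated chain carbon bound to two saturated chain carbons therefore produces no change that can be resolved from the scatter, and on this read-out the branched isobutoxy chain and the unbranched propoxy chain cannot be told apart. No measurement of any property of these compounds bears on this result.

On these data alone, the step covers only the exchange of one methyl for hydrogen, so it remains open whether the number would stay within the scatter with a longer chain such as hexyloxy, or with a chain ending in an amine or a carboxylic acid. Compound 2 differs from compound 1 and from compound 3 at more than one place, so it adds nothing on this change, and the contribution of the other substituents on the shared core remains unresolved.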